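A few compounds are considered here, and "the series" means these few. Any claim that something is new, unique, unknown or untested is made for them only; others in the source may bear on it.

Compound 1 `C(=N/Nc1nc(-c2ccccc2)cs1)\c1ccccc1` and compound 3 `Clc1ccc(/C=N/Nc2nc(-c3ccccc3)cs2)cc1` share one core, and the difference between them is chloro in place of hydrogen on an aromatic carbon. In an assay on mitochondria for inhibition of Amine oxidase [flavin-containing] B (Bos taurus) (a higher number here means a weaker inhibitor, a lower number a stronger inhibitor), compound 1 gives 91.2 nM, and compound 3 gives 170 nM, so the change carried a 1.9-fold higher number from compound 1 to compound 3 (0.27 log units; within the scatter). Compound 2 `Cc1csc(N/N=C/c2ccc(Cl)cc2)n1` stands on a different core; the difference between the two cores is not broken down here. In this assay compound 2 gives 9.12 nM, the lowest of the three values, and the step of a 19-fold higher number from compound 2 to compound 3 (1.27 log units; beyond the scatter) lies well beyond the scatter. Compound 4 `Cc1csc(N/N=C/c2ccc(Cl)cc2Cl)n1` has not yet been measured. It differs from compound 2 by chloro in place of hydrogen on an aromatic carbon, the same kind of change as from compound 1 to compound 3 but not the same: there the entering chloro sits para to a large group, here it sits ortho to a group of 9 heavy atoms and meta to a chloro group. Because the earlier step of a 1.9-fold higher number from compound 1 to compound 3 (0.27 log units; within the scatter) stayed within the scatter, a step of similar modest size is expected here, namely a 1.5-fold higher number from compound 2 to compound 4 (0.19 log units; within the scatter). Compound 4 is accordingly estimated at 14 nM in this assay, within a range from 5 nM to 40 nM.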

Compound 4, inhibition constant: 17 nM
The estimate for compound 4 lay 1.2-fold (0.08 log units) below the measured number, within the range that was stated.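

In this assay, chloro in place of hydrogen gave a 1.9-fold higher number from compound 2 to compound 4 (0.27 log units; within the scatter), a step too small to tell apart from the ordinary variation between repeated measurements. Set beside the earlier step, the same change behaved alike on the two cores: the same change on two cores in this assay, a 1.9-fold higher number (0.27 log units; within the scatter) from compound 1 to compound 3 and a 1.9-fold higher number (0.27 log units; within the scatter) from compound 2 to compound 4, 1.0-fold (0.00 log units) apart, within the scatter of two such steps. Within the data shown here, this agreement shows only that the change stayed within the scatter in both pairs; it does not establish a real effect of the chloro, and two pairs cannot show that the same would hold on another core or at another place on the ring.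

From the compounds shown here alone, what a group other than chloro would do at these places remains open, for example a methoxy group, an amine or a carboxylic acid. Also open, going by these compounds, is whether the large step of phenyl in place of methyl, a 19-fold higher number from compound 2 to compound 3 (1.27 log units; beyond the scatter), would be of similar size with the second chloro of compound 4 on the ring.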